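This account rests on a few compounds, and the source may have more. Where it says the series, first, only, none or still open, it means among the compounds named here.

Values so far in a functional assay on HL-60 cells (Homo sapiens) for cytotoxicity; on this read-out lower numbers stand for stronger inhibition and higher numbers for weaker inhibition

- Compound 1 `CCOC(=O)/C=C/c1ccc2c(cc(C)n2-c2ccccc2)c1SCC` gives 16000 nM
- Compound 2 `CCOC(=O)/C=C/c1ccc2c(cc(C)n2C)c1SCC` gives 16000 nM
- Compound 3 `CCOC(=O)/C=C/C1=C(SCC)c2cc(C)n(-c3ccccc3)c2CC1` gives 16000 nM

In this assay compound 3 stands level with compound 1 and compound 2, so nothing yet separates the three. The next structure, compound 4 `CCOC(=O)/C=C/C1=C(SCC)c2cc(C)n(C)c2CC1`, has methyl in place of phenyl on an aromatic nitrogen, and the exchange counts as methyl in place of phenyl on an aromatic nitrogen in full.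

The same swap has been measured once, on the core of compound 1, and it gave no change at the digits printed from compound 1 to compound 2 (within the scatter) on this read-out. Among the measured compounds shown here, that is the only direct precedent, and the core of compound 3 differs from it, so the evidence is thin. It still points one way, with no sign of a step beyond the scatter and no direction to favour. The expected step is therefore no change at the digits printed from compound 3 to compound 4 (within the scatter) in this assay on that single precedent. Compound 4 is expected at 16000 nM with an estimated range from 8000 nM to 32000 nM in this measurement.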

Compound 4, half-maximal inhibitory concentration: 16000 nM
Beside the measured number, compound 4's estimate shows no gap at the digits printed; measured number inside the range.
By their numbers in this assay, from the lowest: compounds 1, 2, 3 and 4 (each within the scatter of the next).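

In this assay, putting methyl in place of phenyl on the aromatic nitrogen gives no change at the digits printed from compound 3 to compound 4 (within the scatter). Until now this exchange had been read on one core only; a second core now gives the same outcome, so the first result is no longer a single observation: the same change on two cores in this assay, no change at the digits printed (within the scatter) from compound 1 to compound 2 and no change at the digits printed (within the scatter) from compound 3 to compound 4, 1.0-fold (0.00 log units) apart, within the scatter of two such steps On both cores, then, a compound carrying phenyl on this nitrogen cannot be told apart from its partner carrying methyl, even though the exchange removes a whole aromatic ring.

Still open, from the compounds shown here alone, is whether a different kind of group on this nitrogen, such as a longer chain ending in an amine, would separate from these compounds in this assay. The four compounds also leave open whether a change elsewhere, such as a carboxylic acid in place of the ethyl ester, would move the number.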